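Selenium for sulfur on the two-ring core, second instance

A few compounds are considered here, and "the series" means these few. Any claim that something is new, unique, unknown or untested is made for them only; others in the source may bear on it.

Compound 2 `CSc1nc(NCc2ccccc2)c2ccccc2n1` gives 36500 nM in a functional assay on HT-29 cells (Homo sapiens) for cytotoxicity, read by MTT assay, with a stated time of 72 h; a lower number here means a stronger inhibitor of growth, a higher number a weaker inhibitor of growth. Compound 1 `C[Se]c1nc(NCc2ccccc2)c2ccccc2n1` carries the change a group of 2 heavy atoms (1 carbon, 1 selenium; no ring) in place of a group of 2 heavy atoms (1 carbon, 1 sulfur; no ring), on an aromatic carbon on that core and gives 42800 nM in this assay, so the step of a 1.2-fold higher number from compound 2 to compound 1 (0.07 log units; within the scatter). Compound 3 `CSc1ccc(CNc2nc(SC)nc3ccccc23)cc1` differs from compound 2 by methylsulfanyl in place of hydrogen on an aromatic carbon. In this assay compound 3 gives 34700 nM, and the step of a 1.1-fold lower number from compound 2 to compound 3 (0.02 log units; within the scatter). All three numbers sit within the scatter of one another, so no order among them can be read.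

Compound 4 `CSc1ccc(CNc2nc([Se]C)nc3ccccc23)cc1` is not yet measured in this assay. It differs from compound 3 by a group of 2 heavy atoms (1 carbon, 1 selenium; no ring) in place of a group of 2 heavy atoms (1 carbon, 1 sulfur; no ring), on an aromatic carbon. This is the same kind of change as that from compound 2 to compound 1, and the two places are described in nearly the same words.

Going by the values given here, the only measured instance of this change, from compound 2 to compound 1, stayed within the scatter, and the cores of compound 3 and compound 4 carry the methylsulfanyl that compound 2 lacks, an addition that also stayed within the scatter. The expectation for compound 4 is therefore a step of about a 1.2-fold higher number from compound 3 to compound 4 (0.06 log units; within the scatter), resting on the step of a 1.2-fold higher number from compound 2 to compound 1 (0.07 log units; within the scatter). Compound 4 is estimated at 40000 nM in this assay, with a likely range from 22000 nM to 75000 nM.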

Compound 4, concentration for 50% growth inhibition: 72700 nM
For compound 4 the middle estimate is 1.8-fold (0.26 log units) below the measured one; measured number inside the range.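

On the core that carries methylsulfanyl, the exchange of sulfur for selenium in this assay gives a 2.1-fold higher number from compound 3 to compound 4 (0.32 log units; beyond the scatter), and adding methylsulfanyl to the selenium-bearing core gives a 1.7-fold higher number from compound 1 to compound 4 (0.23 log units; within the scatter). The selenium exchange now has two instances, and the gap between them stays inside what two such steps can scatter, so the data show no dependence on the core, even though only the newer step lies beyond the scatter: the same change on two cores in this assay, a 1.2-fold higher number (0.07 log units; within the scatter) from compound 2 to compound 1 and a 2.1-fold higher number (0.32 log units; beyond the scatter) from compound 3 to compound 4, 1.8-fold (0.25 log units) apart, within the scatter of two such steps The methylsulfanyl addition reads the same way, but two instances of each change on a single pair of cores do not show that either change transfers predictably across the wider series, nor do they exclude a modest dependence on the core hidden by the scatter: the same change on two cores in this assay, a 1.1-fold lower number (0.02 log units; within the scatter) from compound 2 to compound 3 and a 1.7-fold higher number (0.23 log units; within the scatter) from compound 1 to compound 4, 1.8-fold (0.25 log units) apart, within the scatter of two such steps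

The compounds shown leave open whether the selenium exchange keeps a similar size when an amine or a carboxylic acid stands in place of the methylsulfanyl on the benzylamine part. They also leave open what happens when a longer chain, such as ethyl or propyl, replaces the methyl on the sulfur or selenium.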